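Sigma-1 binding notes: hexyl to pyridin-2-yl on compound 2

This account rests on a few compounds, and the source may have more. Where it says the series, first, only, none or still open, it means among the compounds named here.

Going by the values given here, compound 2 `CCCCCCN1CCN(CCC(=O)Nc2nc3c(C)cccc3s2)CC1` gives 238 nM in an assay on membranes from brain for displacement of a labelled ligand from Sigma non-opioid intracellular receptor 1 (Cavia porcellus), read by scintillation counting, with a stated time of 120 min (on this read-out higher numbers stand for weaker inhibition and lower numbers for stronger inhibition), and stands lowest among the three numbers measured so far. Compound 1 `Cc1cccc2sc(NC(=O)CCN3CCN(CCCN(C)C)CC3)nc12` gives 570 nM, and compound 3 `Cc1cccc2sc(NC(=O)CCN3CCN(CCN(C(C)C)C(C)C)CC3)nc12` gives 809 nM. Both partners sit beyond the scatter from compound 2: a 2.4-fold lower number from compound 1 to compound 2 (0.38 log units; beyond the scatter), and a 3.4-fold higher number from compound 2 to compound 3 (0.53 log units; beyond the scatter). Between compound 1 and compound 3 the gap is a 1.4-fold higher number from compound 1 to compound 3 (0.15 log units; within the scatter), so those two are not separable on these numbers.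

The next step changes compound 4 `Cc1cccc2sc(NC(=O)CCN3CCN(c4ccccn4)CC3)nc12` relative to compound 2 by pyridin-2-yl in place of hexyl on an amine nitrogen in a ring. The two steps that bear on it both concern the same ring nitrogen: when a plain alkyl chain stood there, the number was lowest, and replacing part of the chain with a nitrogen-bearing group raised it by a modest amount in each case. On these data alone, the entering pyridin-2-yl brings one hydrogen-bond acceptor and an aromatic ring, neither of which has yet been tried at this place, so the aromatic change itself is untested.

On balance the step is expected to raise the number by a 2.9-fold higher number from compound 2 to compound 4 (0.47 log units; beyond the scatter) in this assay, a modest move in the direction seen for compound 3. Compound 4 is therefore estimated at 700 nM, with a range of 250 nM to 2000 nM.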

Compound 4, inhibition constant: 1000 nM
For compound 4 the middle estimate is 1.4-fold (0.15 log units) below the measured one; low and high end bracket the measured number.
By their numbers in this assay, from the lowest: compound 2; then compounds 1, 3 and 4 (each within the scatter of the next).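

Working notes on the amine nitrogen in the ring: with pyridin-2-yl as the first aromatic ring at this place, this assay gives a 4.2-fold higher number from compound 2 to compound 4 (0.62 log units; beyond the scatter) and so a ring of this kind does not keep the level reached with hexyl. Going by these compounds alone, the same change does not separate pyridin-2-yl from the two amine-bearing chains, since a 1.2-fold higher number from compound 3 to compound 4 (0.09 log units; within the scatter) and a 1.8-fold higher number from compound 1 to compound 4 (0.24 log units; within the scatter) leave it level with 2-(diisopropylamino)ethyl and 3-(dimethylamino)propyl, and hexyl in compound 2 is now the one group here set apart from all the others. Nothing at hand accounts for why hexyl alone stands apart at this nitrogen.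

Still open, on these data alone, is whether the ring nitrogen of pyridin-2-yl matters at all, which phenyl at the same place would test, and whether benzyl, with a carbon holding the aromatic ring off the amine nitrogen, falls with pyridin-2-yl or with hexyl. Also open, as far as these compounds go, is how far the lower number of compound 2 depends on chain length, which a shorter chain such as butyl and a longer one such as octyl would show.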